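Swapping the aryl group on a shared two-ring core

The compounds below may be only part of what the source reports. "The series", "measured", "known", "first", "only" and "open" are said of these compounds alone.

Of the compounds shown here, three on one shared core have been measured in a physicochemical assay for lipophilicity, using the shake flask method, in phosphate buffer, measured as octanol-water partition, with a stated time of 85 min, at pH 7.4; a higher number here means a more lipophilic compound, a lower number a more polar compound: compound 1 `O=Cc1ccc(-c2cn3ccnc3c(-c3ccc4ncn(C5CCCCC5)c4c3)n2)cc1` gives 1.5, compound 2 `Cc1cccc(-c2cn3ccnc3c(-c3ccc4ncn(C5CCCCC5)c4c3)n2)c1` gives 1.87, and compound 3 `CCc1ccc(-c2cn3ccnc3c(-c3ccc4ncn(C5CCCCC5)c4c3)n2)cc1` gives 1.66. Compound 2 holds the highest of these three numbers, with compound 3 nearest and compound 1 furthest; the step of a number 0.37 log units higher from compound 1 to compound 2 (beyond the scatter) lies beyond the scatter, while a number 0.21 log units lower from compound 2 to compound 3 (within the scatter) does not. Compound 4 `Fc1ccccc1-c1cn2ccnc2c(-c2ccc3ncn(C4CCCCC4)c3c2)n1` differs from compound 2 by 2-fluorophenyl in place of 3-methylphenyl on an aromatic carbon. Both steps that bear on this exchange of the aryl group stayed modest, so for this assay only a small movement, if any, is expected: a number 0.22 log units lower from compound 2 to compound 4 (within the scatter). Compound 4 is therefore estimated at 1.65, between 1.35 and 1.95.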

Compound 4, partition coefficient: 1.95
The estimate for compound 4 lay 0.30 log units below the measured number; measured number inside the range.
By their numbers in this assay, from the lowest: compounds 1, 3, 2 and 4 (each within the scatter of the next, the first and the last beyond it).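

In this assay the 2-fluorophenyl group on this aromatic carbon next to the ring nitrogen cannot be told apart from the two alkyl-bearing aryl groups, with a number 0.08 log units higher from compound 2 to compound 4 (within the scatter) and a number 0.29 log units higher from compound 3 to compound 4 (within the scatter) as its steps. Against 4-formylphenyl the step is a number 0.45 log units higher from compound 1 to compound 4 (beyond the scatter) and so a second aryl group, besides 3-methylphenyl, stands clear of compound 1, while 4-ethylphenyl does not. Nothing available gives a reason for these numbers. The compounds shown leave open how a phenyl group carrying an amine or a carboxylic acid would read here. They also leave open what a fluorine elsewhere on the phenyl ring would give.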